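From ethoxycarbonyl chain to benzyloxy on the shared core

The source may hold more compounds than are shown below. What is called first, only, known or untested is meant among the compounds shown, and "the series" means these compounds.

Measured in a functional assay on blood (Homo sapiens) for inhibition; on this read-out higher numbers stand for weaker inhibition and lower numbers for stronger inhibition:
Compound 1 `O=C(Nc1cccnc1)Oc1ccc(OCc2nc3ccccc3s2)cc1C1(c2ccccc2)CC2CCC1C2` gives 37 nM; 86 nM; 33 nM (3 entries)
Compound 2 `O=C(O)COc1ccc(OCc2ccc3ccccc3n2)cc1C1(c2ccccc2)CC2CCC1C2` gives > 3000 nM as a limit of the assay
Compound 3 `CCOC(=O)CCCOc1ccc(OCc2ccc3ccccc3n2)cc1C1(c2ccccc2)CC2CCC1C2` gives 150 nM

In this assay, among the compounds with values here, compound 3 holds the only single number of the series. The other two compounds offer none, since compound 1 comes as several entries (the several entries of compound 1 in this assay, 37 nM; 86 nM; 33 nM (3 entries)) and compound 2 only as a limit.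

The next compound is compound 4 `c1ccc(COc2ccc(OCc3ccc4ccccc4n3)cc2C2(c3ccccc3)CC3CCC2C3)cc1` and it differs from compound 3 in one place: phenyl in place of 2-(ethoxycarbonyl)ethyl on a saturated chain carbon bound to an oxygen on an aromatic ring.

Within the data shown here, one measured step bears on this, and only loosely. The large change an at least 20-fold lower number from compound 2 to compound 3 (1.30 log units; beyond the scatter) came when 2-(ethoxycarbonyl)ethyl replaced carboxy, and it starts from a limit. Among the measured compounds shown here, compound 4 has no carboxy either, so that step gives no direction here, and no measured compound carries phenyl at this place.

The expected change is no change at the digits printed from compound 3 to compound 4 (within the scatter) and no step beyond the scatter is foreseen in either direction. For compound 4 the estimate is 150 nM with an expected range from 45 nM to 500 nM in this assay.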

Compound 4, half-maximal inhibitory concentration: > 3000 nM
Compound 4: no number, only a limit (the forecaster's own chance of this, stated with the estimate: 8%); at least 20-fold (1.30 log units) between middle value and limit.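

In this assay, replacing 2-(ethoxycarbonyl)ethyl with phenyl on the saturated chain carbon bound to an oxygen on an aromatic ring brings an at least 20-fold higher number from compound 3 to compound 4 (1.30 log units; beyond the scatter). The earlier step could be read as saying that losing the carboxy group was enough to give a measurable number, but compound 4 also has no carboxy group and still gives only a limit, so that reading does not hold. Of the three compounds that differ at this place, only compound 3, with the 3-(ethoxycarbonyl)propoxy group, gives a number, and compound 4 joins compound 2 at the same limit: the limit of > 3000 nM in this assay, at which 2 of the 4 values shown sit.

The step between compound 2 and compound 4 cannot be read, since both are limits, and so the two cannot be ordered. The compounds shown also leave open whether the number of compound 3 depends on the ester or on the chain itself, a question that a plain butoxy chain, an amide or an amine at the end of the same chain could address.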